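Side-chain change at the amino-acid carbon: working notes

The source may hold more compounds than are shown below. What is called first, only, known or untested is meant among the compounds shown, and "the series" means these compounds.

The series shares one core and differs only in the side chain on the saturated chain carbon bound to an amide-type nitrogen and a carbonyl carbon. Compound 1 `CC[C@H](C)[C@H](NC(=O)CN(c1nc(Cl)nc2c1ncn2C1CCCCO1)C1CC1)C(=O)OCc1ccccc1` gives 22.6% in a functional assay on the whole organism with Mus musculus as the target, with a stated time of 90 min, at a dose of 25 umol/kg by the oral route; a higher number here means a stronger effect of the compound at the dose given, a lower number a weaker effect. Compound 2 `CC(C)(C)OC(=O)NCCCC[C@H](NC(=O)CN(c1nc(Cl)nc2c1ncn2C1CCCCO1)C1CC1)C(=O)OCc1ccccc1` gives 32.9% in this assay, and compound 3 `C[C@@H](O)[C@H](NC(=O)CN(c1nc(Cl)nc2c1ncn2C1CCCCO1)C1CC1)C(=O)OCc1ccccc1` gives 23.4% in this assay. On these three numbers compound 3 stands second; the step of a number 0.8 percentage points higher from compound 1 to compound 3 (within the scatter) and the step of a number 9.5 percentage points lower from compound 2 to compound 3 (within the scatter) both stay inside the scatter, so compound 3 is indistinguishable from either neighbour, while the step of a number 10.3 percentage points higher from compound 1 to compound 2 (beyond the scatter) is the only move beyond the scatter seen so far.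

Compound 4 `CC(C)[C@H](NC(=O)CN(c1nc(Cl)nc2c1ncn2C1CCCCO1)C1CC1)C(=O)OCc1ccccc1` is not yet measured. Relative to compound 3 it carries isopropyl in place of 1-hydroxyethyl on a saturated chain carbon bound to an amide-type nitrogen and a carbonyl carbon. Among the measured compounds shown here, the step that bears most on this is the one from compound 1 to compound 3, which also exchanged a hydroxy against an alkyl group at this chain and was within the scatter; nothing here points to a larger shift. A step of a number 0.4 percentage points lower from compound 3 to compound 4 (within the scatter) in this assay is therefore expected, that is, none beyond the scatter. For compound 4 an activity of 23% is estimated, with a range from 12% to 34%.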

Compound 4, a percentage reported as activity, at one dose (the size of the read-out at that dose, not a potency): 30.1%
Beside the measured number, compound 4's estimate is 7.1 percentage points below it; the range from low to high includes it.
By their numbers in this assay, from the lowest: compounds 1, 3, 4 and 2 (each within the scatter of the next, the first and the last beyond it).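

In this assay the exchange of 1-hydroxyethyl for isopropyl, with the same count of 3 heavy atoms but 1 hydrogen-bond donor and 1 hydrogen-bond acceptor leaving and none entering, gives a number 6.7 percentage points higher from compound 3 to compound 4 (within the scatter) and so shows no step beyond the scatter at this place when the hydroxy goes. The side chain can also lose one methyl, with a number 7.5 percentage points higher from compound 1 to compound 4 (within the scatter) for hydrogen in place of methyl, or trade the long 4-((tert-butoxycarbonyl)amino)butyl for isopropyl, with a number 2.8 percentage points lower from compound 2 to compound 4 (within the scatter) for that exchange, and neither step leaves the scatter, so compound 4 cannot be separated from any of the other three even though compound 1 and compound 2 remain apart. Nothing available gives a reason for the size of any of these steps.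

From the compounds shown here alone, what a side chain carrying a free amine, a carboxylic acid or a phenyl ring would do at this place stays open. All four compounds are also read at one dose and one time, so whether the small steps among them hold at other doses cannot be told from these numbers.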